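A few compounds are considered here, and "the series" means these few. Any claim that something is new, unique, unknown or untested is made for them only; others in the source may bear on it.

Measured so far:
compound 1 `c1ccc(-c2cn3ccnc3c(-c3ccc4ncn(C5CCCCC5)c4c3)n2)cc1`: 65.7%
compound 2 `CC(=O)c1ccc(-c2cn3ccnc3c(-c3ccc4ncn(C5CCCCC5)c4c3)n2)cc1`: 18.5%

In a functional assay on UACC-62 cells (Homo sapiens) for inhibition, read by sulforhodamine B assay, with a stated time of 48 h, tested at 10 uM (a higher number here means more inhibition at the concentration tested (going by the name of the read-out), a lower number less inhibition), compound 1 gives 65.7%, while compound 2 gives 18.5%, the lower of the two numbers; that step was a number 47.2 percentage points lower from compound 1 to compound 2 (beyond the scatter). Compound 3 `COc1ccccc1-c1cn2ccnc2c(-c2ccc3ncn(C4CCCCC4)c3c2)n1` is not yet measured. Compared with compound 2, (2-methoxyphenyl in place of 4-acetylphenyl on an aromatic carbon). Within the data shown here, only one measured step bears on this change: because a number 47.2 percentage points lower from compound 1 to compound 2 (beyond the scatter) followed the acetyl entering, its leaving in compound 3 is expected to move the number back up in this assay, although the entering 2-methoxyphenyl has no counterpart among the measured compounds, so the size is uncertain. Compound 3 is therefore expected to give about 50%, somewhere between 20% and 80%, a step of a number 31.5 percentage points higher from compound 2 to compound 3 (beyond the scatter).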

Compound 3, a percentage reported as inhibition, at one concentration (the size of the read-out at that concentration, not a potency): 25.1%
Compound 3: middle estimate off by 24.9 percentage points, on the high side; measured number inside the range.
By their numbers in this assay, from the lowest: compounds 2 and 3 (each within the scatter of the next); then compound 1.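

In this assay, 2-methoxyphenyl in place of 4-acetylphenyl gives a number 6.6 percentage points higher from compound 2 to compound 3 (within the scatter) and so no readable difference, whereas methoxy in place of hydrogen gives a number 40.6 percentage points lower from compound 1 to compound 3 (beyond the scatter) as a clear loss. The loss at this position is therefore not tied to acetyl alone, since the 2-methoxyphenyl of compound 3 also falls well short of the unsubstituted phenyl of compound 1. No measurement here explains this loss. Still open, going by these compounds, is whether a fluorine or an amine on this phenyl ring would also lower the number.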